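Replacing the chlorophenyl on the piperazine of compound 1 with pyrazinyl

The source may report more compounds than this note shows. Statements on the series, on what has been measured and on what is new or still open speak of the compounds shown alone.

This account follows a benzamide bearing a dithiocarbamate-linked piperazine. Compound 1 `Nc1ccccc1NC(=O)c1ccc(CSC(=S)N2CCN(c3ccc(Cl)cc3)CC2)cc1` was tested in a functional assay on MGC-803 cells (Homo sapiens) for antiproliferative activity, read by CCK-8 assay, with a stated time of 72 h, tested at 8 uM (on this read-out higher numbers stand for a stronger effect at the one concentration tested and lower numbers for a weaker effect), and gave 17.2%, the lower of the two measured numbers. Compound 2 `CC1CCN(C(=S)SCc2ccc(C(=O)Nc3ccccc3N)cc2)CC1`, which carries a different ring on the dithiocarbamate, gave 81.9% in this assay, a gap that lies well beyond the scatter of repeated measurements. Compound 3 `Nc1ccccc1NC(=O)c1ccc(CSC(=S)N2CCN(c3cnccn3)CC2)cc1` has not yet been measured in this assay. It differs from compound 1 in one place: pyrazin-2-yl in place of 4-chlorophenyl on an amine nitrogen in a ring. Among the compounds with values here, no measured pair traces this particular change, so any expectation rests on compound 1 alone and on the wide spread that compound 2 shows is possible. The step from compound 1 to compound 3 is expected to be a moderate rise, a number 14.8 percentage points higher from compound 1 to compound 3 (beyond the scatter), though it may fall within the scatter. Compound 3 is accordingly estimated at 32%, with a range from 10% to 60%.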

Compound 3, a percentage reported as inhibition, at one concentration (the size of the read-out at that concentration, not a potency): 80.5%
Estimate against measurement, compound 3: 48.5 percentage points below; the whole stated range lies below it.
By their numbers in this assay, from the lowest: compound 1; then compounds 3 and 2 (each within the scatter of the next).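

In this assay the exchange of 4-chlorophenyl for pyrazin-2-yl on the amine nitrogen in the ring gives a number 63.3 percentage points higher from compound 1 to compound 3 (beyond the scatter) and shows that this position strongly affects the read-out at the one concentration tested. Compound 3 still carries a six-membered aromatic ring at this nitrogen, so the presence of such a ring does not in itself go with the low number of compound 1. No measurement shown here bears on why this step is so large.

From the compounds shown here alone, whether the rise follows the two ring nitrogens of pyrazin-2-yl or the departure of the chlorine remains open, and an unsubstituted phenyl or a pyridinyl at this nitrogen would help to separate the two. Going by these compounds, how a pyrimidinyl, with its ring nitrogens placed differently, would compare also remains open.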